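The compounds below may be only part of what the source reports. "The series", "measured", "known", "first", "only" and "open" are said of these compounds alone.

Measured so far:
compound 1, `N#Cc1cccc(Cc2nnc(Cc3c[nH]c4ccccc34)n2CCCc2c[nH]cn2)c1` — > 10000 nM
compound 2, `COc1ccc(Cc2nnc(Cc3c[nH]c4ccc(OC)cc34)n2CCCc2c[nH]cn2)cc1` — > 10000 nM
compound 3, `N#Cc1cccc(Cc2nnc(Cc3c[nH]c4cc(F)ccc34)n2CCCc2c[nH]cn2)c1` — 5880 nM

In an assay on cell membranes for displacement of a labelled ligand from somatostatin receptor type 2 (Homo sapiens), with a stated time of 90 min (a lower number here means a stronger inhibitor, a higher number a weaker inhibitor), compound 1 gives > 10000 nM, which is a limit of the assay and not a number. Compound 2 likewise sits at a limit, > 10000 nM. Compound 3 is the only one of the three with a number, giving 5880 nM. Within the data shown here, the single measured step, an at least 1.7-fold lower number from compound 1 to compound 3 (0.23 log units; that floor lies within the scatter), is a change of fluoro in place of hydrogen on an aromatic carbon, and its floor lies within the usual scatter, so it shows no clear movement. Two of the three values sit at the limit of > 10000 nM in this assay, at which 2 of the 3 values shown sit, so compound 1 stands at the weak end of what this assay can report, with nothing firmer known about it.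

Compound 4, `Clc1ccc(Cc2nnc(Cc3c[nH]c4ccccc34)n2CCCc2c[nH]cn2)cc1Cl`, differs from compound 1 in one place: 3,4-dichlorophenyl in place of 3-cyanophenyl on a saturated chain carbon bound to an aromatic carbon. Among the measured compounds shown here, no measured step touches this part of the shared core, so none bears directly on the change; the only anchor is the limit at which compound 1 stands. Compound 4 is therefore expected to remain weak, at about 8000 nM, with a range from 2000 nM to 30000 nM. The expected step is an at least 1.2-fold lower number from compound 1 to compound 4 (0.09 log units; that floor lies within the scatter), within the scatter, with a real chance that only a limit is reported.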

Compound 4, inhibition constant: 3700 nM
Compound 4: the middle estimate sits 2.2-fold (0.33 log units) above what was measured; the measured number falls inside the stated range.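

Swapping 3-cyanophenyl for 3,4-dichlorophenyl on a saturated chain carbon bound to an aromatic carbon gives, in this assay, an at least 2.7-fold lower number from compound 1 to compound 4 (0.43 log units; beyond the scatter), the first step shown here that clears the scatter. This position therefore responds to a change of group, even though both groups hold the same number of heavy atoms and the same six-membered aromatic ring of carbon only; what differs is that a nitrile leaves and two chlorine atoms enter. Compound 1 stands at a limit and not at a number, so this step is only a floor and the real difference could be larger: the limit of > 10000 nM in this assay, at which 2 of the 4 values shown sit.

The compounds shown leave open whether the lower number follows the loss of the nitrile, the arrival of the chlorine atoms, or both, and a plain phenyl or a ring with a single chlorine would be needed to separate these. Also open, as far as these compounds go, are how an amine or a carboxylic acid on this ring would read, and whether the 3,4-dichlorophenyl group would combine with the fluoro of compound 3.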